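The source may report more compounds than this note shows. Statements on the series, on what has been measured and on what is new or still open speak of the compounds shown alone.

Working notes on the series. Compound 2, `CNC(=O)N1CCCc2ccc(NC(=O)c3cccc(-c4ccn(C)n4)c3)cc21`, stands highest of the two numbers recorded in a functional assay on MV4-11 cells (Homo sapiens) for antiproliferative activity, with a stated time of 6 days, tested at 1.56 uM; on this read-out higher numbers stand for a stronger effect at the one concentration tested and lower numbers for a weaker effect: in this assay compound 2 gives 70.5%. Among the measured compounds shown here, its nearest neighbour is compound 1, `CNC(=O)N1CCCc2ccc(NC(=O)c3ccc(-c4ccccc4)cc3)cc21`, which also carries a phenyl on the benzamide and in this assay gives 19.7%, a gap beyond the scatter; no single-point step between compound 1 and compound 2 is set out, so only their two values are read side by side.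

Compound 3, `CNC(=O)N1CCCc2ccc(NC(=O)c3cccc(-c4ccccc4)c3)cc21`, is not yet measured in this assay. It differs from compound 2 as follows: phenyl in place of 1-methyl-1H-pyrazol-3-yl on an aromatic carbon. The two hydrogen-bond acceptors of the 1-methyl-1H-pyrazol-3-yl are lost in the exchange.

For the measured compounds named here, with no measured step for this kind of exchange, the expectation rests on the weak result of compound 1 with its phenyl, 19.7%, against the stronger result of compound 2. A drop beyond the scatter is expected, a number 30.5 percentage points lower from compound 2 to compound 3 (beyond the scatter). Compound 3 is therefore estimated at 40%, within a range from 10% to 72%.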

Compound 3, a percentage reported as inhibition, at one concentration (the size of the read-out at that concentration, not a potency): 2.83%
For compound 3 the middle estimate is 37.2 percentage points above the measured one, outside the stated range (below it).
By their numbers in this assay, from the lowest: compound 3; then compound 1; then compound 2.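

Phenyl in place of 1-methyl-1H-pyrazol-3-yl, on an aromatic carbon meta to a large group, gives a number 67.7 percentage points lower from compound 2 to compound 3 (beyond the scatter) in this assay. This step shows that the read-out at this position depends on which ring is attached, not on its heavy-atom count: both groups have 6 heavy atoms, no hydrogen-bond donors and no net charge, while the ring size, the ring nitrogens and the 2 hydrogen-bond acceptors of the leaving group differ. No measurement shown bears on the cause of the step.

From the compounds shown here alone, it remains open which of these differences carries the step, and whether the methyl on the pyrazole contributes. A pyridyl ring or an unmethylated pyrazole on the same carbon would bear on that question, and a morpholine or a simple amine would test whether an aromatic ring is needed there at all.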